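The source may hold more compounds than are shown below. What is called first, only, known or untested is meant among the compounds shown, and "the series" means these compounds.

Measured in a functional assay on A549 cells (Homo sapiens) for antiproliferative activity, read by CCK-8 assay, with a stated time of 72 h; on this read-out higher numbers stand for weaker inhibition of growth and lower numbers for stronger inhibition of growth:
- compound 1 `CCCNC(=O)c1ccc2c(ccn2-c2ncc3c(n2)N(c2ccn(C)n2)C(CC)C(=O)N3C)c1`: "not active" (no number reported)
- compound 2 `CCCCNC(=O)c1ccc2c(ccn2-c2ncc3c(n2)N(c2ccn(C)n2)C(CC)C(=O)N3C)c1`: 37300 nM

Going by the values given here, compound 2 provides the only number so far, 37300 nM. Compound 1 returned no number, so compound 2 cannot be ranked numerically against it. Compound 3 `CCC1C(=O)N(C)c2cnc(-n3ccc4cc(C(=O)NC5CCCC5)ccc43)nc2N1c1ccn(C)n1` has not yet been measured in this assay. It places cyclopentyl in place of butyl on an amide-type nitrogen. Among the compounds with values here, no measured step between compounds differing in one place is available, so the expectation rests on compound 2 at 37300 nM and on this structural change. No shift beyond the scatter, in either direction, is expected. The estimated change is a 1.2-fold lower number from compound 2 to compound 3 (0.09 log units; within the scatter). A result without a number, as for compound 1, remains possible. For compound 3 the estimated value is 30000 nM, with an expected range of 10000 nM to 90000 nM.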

Compound 3, concentration for 50% growth inhibition: 39500 nM
Estimate against measurement, compound 3: 1.3-fold (0.12 log units) below; low and high end bracket the measured number.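

In this assay, going by these compounds alone, cyclopentyl in place of butyl on the amide-type nitrogen gives a 1.1-fold higher number from compound 2 to compound 3 (0.02 log units; within the scatter) and provides the first step that can be read as a number. At this position, therefore, an open butyl chain and a five-membered carbon ring are not told apart by this read-out, and closing the chain into a ring with one more carbon leaves the result within the scatter. No measured evidence accompanies this result to account for it.

Compound 1 gives "not active" (no number reported) and offers no number, so its steps to the other two compounds cannot be read. Going by these compounds, it remains open whether a longer chain, a phenyl ring or a terminal amine on this nitrogen would move the number beyond the scatter, in either direction.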